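Swapping a Nitrile for a Phenoxy Group on the Benzyl Ether

A few compounds are considered here, and "the series" means these few. Any claim that something is new, unique, unknown or untested is made for them only; others in the source may bear on it.

Of the compounds shown here, two built on the shared core have been measured. Compound 1 `COc1cc(OCc2cccc(CCc3ccccc3)c2)c2cc(-c3cn4nc(OC)sc4n3)oc2c1` gives 2.4 nM in a functional assay on HEK293 cells for antagonist activity at proteinase-activated receptor 4 (Homo sapiens), read by FLIPR and calcium flux, with a stated time of 30 min; on this read-out higher numbers stand for weaker inhibition and lower numbers for stronger inhibition. Compound 2 `COc1cc(OCc2cccc(C#N)c2)c2cc(-c3cn4nc(OC)sc4n3)oc2c1` gives 0.98 nM in this assay, the lowest of the two numbers, so it is the stronger inhibitor of the pair. For the measured compounds named here, the only step available, a 2.4-fold lower number from compound 1 to compound 2 (0.39 log units; beyond the scatter), is modest but beyond the scatter. Compound 3 `COc1cc(OCc2cccc(Oc3ccccc3)c2)c2cc(-c3cn4nc(OC)sc4n3)oc2c1` differs from compound 2 by phenoxy in place of cyano on an aromatic carbon. Because a 2.4-fold lower number from compound 1 to compound 2 (0.39 log units; beyond the scatter) fell when a phenethyl group, with its six-membered aromatic ring of carbon only, gave way to a cyano group with no ring, bringing in phenoxy with such a ring is expected to move the number back toward that of compound 1, with a rise beyond the scatter likely. For compound 3 the expected step is a 2.2-fold higher number from compound 2 to compound 3 (0.35 log units; beyond the scatter). Compound 3 is estimated at 2.2 nM, within a range from 0.8 nM to 6 nM.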

Compound 3, half-maximal inhibitory concentration: 1.2 nM
Compound 3: middle estimate off by 1.8-fold (0.26 log units), on the high side, within the range that was stated.
By their numbers in this assay, from the lowest: compounds 2, 3 and 1 (each within the scatter of the next, the first and the last beyond it).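

Phenoxy and cyano cannot be told apart at this position in this assay (a 1.2-fold higher number from compound 2 to compound 3 (0.09 log units; within the scatter)), so a six-membered aromatic ring of carbon only, brought onto this aromatic carbon, does not by itself separate a compound from compound 2. Phenoxy and phenethyl, which both carry that ring, cannot be told apart either (a 2.0-fold lower number from compound 1 to compound 3 (0.30 log units; within the scatter)). Compound 3 therefore sits within the scatter of both neighbours, even though compound 1 and compound 2 lie beyond the scatter of each other, and the three groups so far span only a small part of what this position might accept.

As far as these compounds go, whether an amine, a carboxylic acid or a longer chain on this carbon would stay as close to these numbers remains open. Nothing in the data shown gives a reason for how closely these groups read.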